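Piperazin-1-yl replacing (1-phenylethyl)amino: working notes

The compounds below may be only part of what the source reports. "The series", "measured", "known", "first", "only" and "open" are said of these compounds alone.

Three compounds share the core of compound 1 and have entries for a functional assay on MCF7 cells (Homo sapiens) for cytotoxicity, read by MTT assay, with a stated time of 72 h; a lower number here means a stronger inhibitor, a higher number a weaker inhibitor. In this assay, within the data shown here, compound 1 (`Nc1cccc(Nc2c(C(=O)NCc3ccc(F)cc3)nc(Br)c3cccnc23)c1`) gives 8000 nM, the only true number so far. Compound 2 (`CC(C)(C)OC(=O)N1CCN(c2c(C(=O)NCc3ccc(F)cc3)nc(Br)c3cccnc23)CC1`) is recorded at > 10000 nM, which is a limit of the assay and not a number. For compound 3 (`C[C@H](Nc1c(C(=O)NCc2ccc(F)cc2)nc(Br)c2cccnc12)c1ccccc1`) the entry reads "not determined" (no result reported), with no result reported, so compound 3 has no position on the potency scale and gives the next step no measured starting point.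

Compound 4 (`O=C(NCc1ccc(F)cc1)c1nc(Br)c2cccnc2c1N1CCNCC1`) has yet to be measured. The structural step is piperazin-1-yl in place of (1-phenylethyl)amino on an aromatic carbon, para to a bromo group.

Among the measured compounds shown here, no step between measured compounds is available, so the size of this change in this assay cannot be calibrated. With no starting number, no direction can be assigned to it either. For the measured compounds named here, the expectation is only that compound 4 will fall in the same weak range as the other entries. That expectation rests on compound 1 at 8000 nM. A second reference point is the limit of > 10000 nM in this assay, at which 1 of the 3 values shown sits, and a reading at that limit remains a real possibility. For compound 4 the expected value is 7000 nM, with an estimated range of 2500 nM to 12000 nM.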

Compound 4, half-maximal inhibitory concentration: 7000 nM
Beside the measured number, compound 4's estimate shows no gap at the digits printed; measured number inside the range.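

In this assay, piperazin-1-yl in place of (3-aminophenyl)amino on the aromatic carbon para to a bromo group gives a 1.1-fold lower number from compound 1 to compound 4 (0.06 log units; within the scatter). Among these compounds, this is the first step between two true numbers, and it shows that an aromatic amine and a saturated ring amine at this position cannot be told apart in this read-out. Hydrogen in place of tert-butoxycarbonyl on the amine nitrogen in the ring gives an at least 1.4-fold lower number from compound 2 to compound 4 (0.15 log units; that floor lies within the scatter), so this step does not separate the two compounds either, and compound 2 remains a limit of the assay rather than a number: the limit of > 10000 nM in this assay, at which 1 of the 4 values shown sits.

The step from the (1-phenylethyl)amino of compound 3 to the piperazin-1-yl of compound 4 cannot be read, as compound 3 has no result to compare. Still open, going by these compounds, is whether any group at this position moves the number beyond the scatter, for example a morpholin-4-yl ring, a piperazine carrying a methyl group on its ring nitrogen, or a carboxylic acid on the aniline ring.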